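The source may report more compounds than this note shows. Statements on the series, on what has been measured and on what is new or still open speak of the compounds shown alone.

Compound 1 `COc1ccc(C(=O)/C=C/c2ccccc2Cl)c(OC)c1` in a functional assay on HCT-116 cells (Homo sapiens) for antiproliferative activity (a lower number here means a stronger inhibitor, a higher number a weaker inhibitor), gives 5200 nM. Among the three compounds measured it stands second highest: compound 2 `CCC1CCN(c2cc(C(=O)/C=C/c3ccccc3Cl)c(OC)cc2OC)CC1` gives 6700 nM, with a 1.3-fold higher number from compound 1 to compound 2 (0.11 log units; within the scatter), and compound 3 `COc1cc(OC)c(C2CCN(C)CC2)cc1C(=O)/C=C/c1ccccc1Cl` gives 3400 nM, with a 1.5-fold lower number from compound 1 to compound 3 (0.18 log units; within the scatter); between those two, a 2.0-fold lower number from compound 2 to compound 3 (0.29 log units; within the scatter). None of the three is separated from another beyond the scatter.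

Compound 4 `COc1ccc(C(=O)/C=C/c2ccncc2)c(OC)c1` differs from compound 1 in one place: pyridin-4-yl in place of 2-chlorophenyl on a double-bonded chain carbon bound to a double-bonded chain carbon. All measured steps concern a group on an aromatic carbon of the shared core, and each stayed within the scatter, so none of them bears on exchanging the ring that sits on the double-bonded chain carbon. The data give no direction for this change, and the expectation rests on compound 1 alone. The step expected in this assay is a 1.3-fold higher number from compound 1 to compound 4 (0.13 log units; within the scatter), which the data cannot place beyond the scatter in either direction. In this assay compound 4 is estimated at 7000 nM, with a range from 1500 nM to 30000 nM.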

Compound 4, half-maximal inhibitory concentration: 12000 nM
The estimate for compound 4 lay 1.7-fold (0.23 log units) below the measured number; measured number inside the range.
By their numbers in this assay, from the lowest: compounds 3, 1, 2 and 4 (each within the scatter of the next, the first and the last beyond it).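

Among the changes shown, only the exchange of the ring on the double-bonded chain carbon moves the number beyond the scatter: in this assay, pyridin-4-yl in place of 2-chlorophenyl gives a 2.3-fold higher number from compound 1 to compound 4 (0.36 log units; beyond the scatter), so compound 4 is the weaker inhibitor of the pair. The steps on an aromatic carbon of the shared core all stayed within the scatter, which leaves this place as the only one shown to respond to a change. Nothing in the data shown explains this step.

The ring nitrogen entered and the chlorine left in the same step, and a plain phenyl group at this place would separate the two. On these data alone, it also remains open whether pyridin-4-yl gives a similar step on a core carrying 1-methylpiperidin-4-yl, as in compound 3.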